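Solubility notes: indolylmethyl in place of methoxypyridinylmethyl

The source may hold more compounds than are shown below. What is called first, only, known or untested is meant among the compounds shown, and "the series" means these compounds.

Among the measured compounds shown here, in a physicochemical assay for solubility, read by spectrophotometry, in phosphate buffer, with a stated time of 2 h, at pH 7.4 (a higher number here means a more soluble compound, a lower number a less soluble compound), compound 3 `COc1ccc2[nH]c(C(=O)N3CC(=O)N(Cc4cccc(OC)n4)[C@@H](Cc4ccccc4)C3)cc2c1` gives 47500 nM, the highest of the three numbers measured so far. Compound 1 `COc1ccc2[nH]c(C(=O)N3CC(=O)N(Cc4ccccc4)[C@@H](CN4CCN(S(=O)(=O)c5ccccc5)CC4)C3)cc2c1` gives 16900 nM in this assay, the nearest number to compound 3, with the gap beyond the scatter. Compound 2 `Cc1ccc2[nH]c(C(=O)N3CC(=O)N(Cc4ccccc4)[C@@H](CN4CCC5(CCC5)CC4)C3)cc2c1` gives 12300 nM, the furthest from compound 3, also beyond the scatter. For the measured compounds named here, no pair of measured compounds differs in one place only, so no measured single step is available to lean on. Compound 4 `COc1ccc2[nH]c(C(=O)N3CC(=O)N(Cc4c[nH]c5ccccc45)[C@@H](Cc4ccccc4)C3)cc2c1` differs from compound 3 by 1H-indol-3-yl in place of 6-methoxypyridin-2-yl on a saturated chain carbon bound to an amide-type nitrogen in a ring. The change removes the two hydrogen-bond acceptors counted there and brings one hydrogen-bond donor. The expected step is a 3.2-fold lower number from compound 3 to compound 4 (0.50 log units; beyond the scatter), a drop beyond the scatter. Compound 4 is expected to give about 15000 nM in this assay, within 5000 nM to 45000 nM.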

Compound 4, solubility: 10300 nM
Estimate against measurement, compound 4: 1.5-fold (0.16 log units) above; the measured number falls inside the stated range.
By their numbers in this assay, from the lowest: compounds 4, 2 and 1 (each within the scatter of the next); then compound 3.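

In this assay the series now has its first single-place step, running a 4.6-fold lower number from compound 3 to compound 4 (0.66 log units; beyond the scatter) and lying beyond the scatter. On a saturated chain carbon bound to an amide-type nitrogen in a ring, the number therefore responds to the group carried there, and 1H-indol-3-yl sits lower than 6-methoxypyridin-2-yl. No supporting measurement accompanies this step to account for its size. This one pair cannot separate the methoxy group from the ring exchanged with it. From the compounds shown here alone, how an unsubstituted pyridin-2-yl, a dimethylamino group or a carboxylic acid would read at this place remains open.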